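Swapping the Ring on the Sulfur-Linked Chain

The compounds below may be only part of what the source reports. "The series", "measured", "known", "first", "only" and "open" are said of these compounds alone.

Compound 2 `Cc1cc(N2CC[C@@H](C)[C@@H](N(C)c3ncnc4[nH]ccc34)C2)n2nc(SCc3ccc(C(F)(F)F)cc3)nc2n1` gives the lowest number of the three measured compounds in a functional assay on MGC-803 cells (Homo sapiens) for inhibition, read by MTT assay, with a stated time of 72 h (on this read-out higher numbers stand for weaker inhibition and lower numbers for stronger inhibition), where compound 2 reaches 2680 nM. Compound 1 `CCCSc1nc2nc(C)cc(N3CC[C@@H](C)[C@@H](N(C)c4ncnc5[nH]ccc45)C3)n2n1` gives 15500 nM in this assay, and compound 3 `C[C@@H]1CCN(c2cc(-c3ccccc3)nc3ncnn23)C[C@@H]1N(C)c1ncnc2[nH]ccc12` gives 84900 nM; both steps from these to compound 2 lie beyond the scatter, so compound 2 is the strongest inhibitor of the three. Compound 4 `Cc1cc(N2CC[C@@H](C)[C@@H](N(C)c3ncnc4[nH]ccc34)C2)n2nc(SCc3ccccc3Br)nc2n1` differs from compound 2 in one place: 2-bromophenyl in place of 4-(trifluoromethyl)phenyl on a saturated chain carbon bound to a sulfur. Among the compounds with values here, the only measured step that touches the same place is a 5.8-fold lower number from compound 1 to compound 2 (0.76 log units; beyond the scatter), which shows that the group on the saturated chain carbon bound to a sulfur can move the number by a modest amount. Within the data shown here, no measured pair compares two different ring groups at that place, so the direction of the new exchange is not fixed by the data. The expected step is a 1.5-fold higher number from compound 2 to compound 4 (0.17 log units; within the scatter), a small change that may stay within the scatter. Compound 4 is therefore estimated at 4000 nM, between 1300 nM and 12000 nM.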

Compound 4, half-maximal inhibitory concentration: 27000 nM
Compound 4: the middle estimate sits 6.8-fold (0.83 log units) below what was measured; the whole stated range lies below it.
By their numbers in this assay, from the lowest: compound 2; then compounds 1 and 4 (each within the scatter of the next); then compound 3.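

In this assay, the two ring groups at this place are not interchangeable: 2-bromophenyl in place of 4-(trifluoromethyl)phenyl gives a clear loss (a 10-fold higher number from compound 2 to compound 4 (1.00 log units; beyond the scatter)). A ring on the saturated chain carbon bound to a sulfur therefore does not guarantee the stronger inhibition seen with compound 2, as replacing ethyl with 2-bromophenyl gives no change beyond the scatter (a 1.7-fold higher number from compound 1 to compound 4 (0.24 log units; within the scatter)). No supporting measurement is available to explain the gap between the two rings.

This exchange alters both the substituent and its place on the ring, and the compounds shown do not separate those two changes. On these data alone, what 4-bromophenyl, 2-(trifluoromethyl)phenyl or unsubstituted phenyl would give at this place remains open.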